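Side-chain amine variation on a bicyclic histamine antagonist core

A few compounds are considered here, and "the series" means these few. Any claim that something is new, unique, unknown or untested is made for them only; others in the source may bear on it.

Measured so far:
- compound 1, `Cc1cc(C)c2ccc(=O)n(CCN(C)C)c2n1`: 3.93 ug/mL
- compound 2, `Cc1nc2c(ccc(=O)n2CCN(C)C)c(C)c1C`: 12.5 ug/mL

In an assay on isolated protein (strain Charles River) for antagonist activity at histamine H2 receptor (Rattus norvegicus) (a lower number here means that less compound is needed, a higher number that more compound is needed for the effect), compound 1 gives the lowest of the two numbers; its nearest neighbour is compound 2, and the step of a 3.2-fold higher number from compound 1 to compound 2 (0.50 log units; beyond the scatter) shows how far apart they lie. Compound 3, `CCN(CC)CCn1c(=O)ccc2c(C)cc(C)nc21`, is not yet measured. It differs from compound 1 by diethylamino in place of dimethylamino on a saturated chain carbon, two bonds along the chain from an aromatic nitrogen. Going by the values given here, no measured step touches this part of the molecule: the only step on record, a 3.2-fold higher number from compound 1 to compound 2 (0.50 log units; beyond the scatter), concerns a methyl on the aromatic core and says nothing about the chain amine. Among the compounds with values here, with no step bearing on the change, the expectation for compound 3 rests on compound 1 alone, and a step of no more than the scatter is expected, a 1.1-fold higher number from compound 1 to compound 3 (0.06 log units; within the scatter). Compound 3 is therefore estimated at 4.5 ug/mL in this assay, with a range from 1.5 ug/mL to 14 ug/mL.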

Compound 3, half-maximal effective concentration: 1.12 ug/mL
Beside the measured number, compound 3's estimate is 4.0-fold (0.60 log units) above it; measured number outside the range, below it.
By their numbers in this assay, from the lowest: compound 3; then compound 1; then compound 2.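

The chain amine proves to be a place where the number moves in this assay: with diethylamino in place of dimethylamino, the change gives a step beyond the scatter (a 3.5-fold lower number from compound 1 to compound 3 (0.55 log units; beyond the scatter)). Going by these compounds alone, the only earlier step concerned a methyl on an aromatic carbon and ran the other way (a 3.2-fold higher number from compound 1 to compound 2 (0.50 log units; beyond the scatter)), so the side chain can shift the number on its own, with the core of compound 1 left unchanged. Nothing available explains why diethylamino gives the lower number.

From the compounds shown here alone, it remains open whether the trend continues with dipropylamino, or what a cyclic amine such as piperidine or a longer chain to the aromatic nitrogen would give. Going by these compounds, it is also open whether diethylamino lowers the number in the same way on the core of compound 2.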